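From cyclohexyl to 2-hydroxy-2-methylpropyl on the shared core

This account rests on a few compounds, and the source may have more. Where it says the series, first, only, none or still open, it means among the compounds named here.

In an ADME assay on BaF3 cells (Mus musculus) for cytotoxicity, read by MTT assay, with a stated time of 48 h (a lower number here means a stronger inhibitor of growth, a higher number a weaker inhibitor of growth), compound 1 `CC(C)n1nc(-c2cc(C(C)(C)C)on2)c2c(N)ncnc21` gives > 10000 nM, which is a limit of the assay and not a number. In this assay compound 2 `Nc1ncnc2c1c(-c1cc(C3CC3)on1)nn2C1CCCCC1` gives > 10000 nM, and this too is only a limit. The picture so far is the limit of > 10000 nM in this assay, at which 2 of the 2 values shown sit, so neither compound has a measured number. Compound 3 `CC(C)(O)Cn1nc(-c2cc(C3CC3)on2)c2c(N)ncnc21` keeps the 5-cyclopropyl-1,2-oxazol-3-yl group of compound 2 and carries 2-hydroxy-2-methylpropyl in place of cyclohexyl on an aromatic nitrogen. Among the compounds with values here, no measured pair shows what such a change does. No shift beyond the usual scatter is expected in this assay, in either direction. The estimated step is a number no higher from compound 2 to compound 3 (the limit leaves the size open). This expectation leans on compound 2, whose > 10000 nM is a limit. Compound 3 is expected near 10000 nM, with an estimated range of 4000 nM to 20000 nM.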

Compound 3, concentration for 50% growth inhibition: > 10000 nM
Compound 3 was reported as a limit (the forecaster's own chance of this, stated with the estimate: 85%); the middle value lies on the limit itself.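

In this assay no step can be read from compound 2 to compound 3, because both results are limits of the assay and not numbers: the limit of > 10000 nM in this assay, at which 3 of the 3 values shown sit.

The compounds shown leave open whether 2-hydroxy-2-methylpropyl in place of cyclohexyl on an aromatic nitrogen changes growth inhibition at all, and how strongly any of the three compounds inhibits growth.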